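This account rests on a few compounds, and the source may have more. Where it says the series, first, only, none or still open, it means among the compounds named here.

Three compounds of this series carry measured numbers in a functional assay on U-87MG ATCC cells for inhibition, with U-87 MG (Homo sapiens) as the target, read by MTT assay, with a stated time of 72 h; on this read-out lower numbers stand for stronger inhibition and higher numbers for weaker inhibition. Compound 1 `Oc1c(C(c2ccc(F)cc2)N2CCCCC2)ccc2cccnc12` gives 37000 nM, compound 2 `CCc1ccc(C(Nc2ccccn2)c2ccc3cccnc3c2O)cc1` gives 9300 nM, and compound 3 `CCc1ccc(C(Nc2cc(C)ccn2)c2ccc3cccnc3c2O)cc1` gives 8900 nM. Compound 2 and compound 3 therefore sit within the scatter of each other, while compound 1 stands at a clearly higher number than compound 2. Within the data shown here, the one step measured between neighbours, a 1.0-fold lower number from compound 2 to compound 3 (0.02 log units; within the scatter), is a change on the aromatic ring bound to the nitrogen and says nothing about the carbon-bound aryl group.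

Compound 4 `Cc1ccc(C)c(C(Nc2ccccn2)c2ccc3cccnc3c2O)c1` differs from compound 2 only at that aryl group: 2,5-dimethylphenyl in place of 4-ethylphenyl on a saturated chain carbon bound to an aromatic carbon and a nitrogen on an aromatic ring. Among the measured compounds shown here, no measured pair speaks to this change; the only step with a single difference lies elsewhere on the core and stays within the scatter. With nothing to indicate a shift in either direction, compound 4 is expected to stay near compound 2 in this assay, the expected step being a 1.3-fold higher number from compound 2 to compound 4 (0.11 log units; within the scatter). The estimate for compound 4 is 12000 nM, within a range from 4000 nM to 35000 nM.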

Compound 4, half-maximal inhibitory concentration: 13800 nM
The estimate for compound 4 lay 1.2-fold (0.06 log units) below the measured number; measured number inside the range.
By their numbers in this assay, from the lowest: compounds 3, 2 and 4 (each within the scatter of the next); then compound 1.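

Among these compounds, the step of a 1.5-fold higher number from compound 2 to compound 4 (0.17 log units; within the scatter) is the first measured change at this position, on a saturated chain carbon bound to an aromatic carbon and a nitrogen on an aromatic ring. In this assay, 2,5-dimethylphenyl in place of 4-ethylphenyl rearranges the same eight carbons on the aryl group and leaves the two compounds within the scatter of each other, so this particular rearrangement does not separate them. Nothing available here gives a reason for this result.

The compounds shown leave open whether a carboxylic acid, an amine or a methoxy group on this aryl ring would carry the number beyond the scatter. They also leave open whether the methyl on the nitrogen-bound ring of compound 3 would behave the same way alongside 2,5-dimethylphenyl.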